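A few compounds are considered here, and "the series" means these few. Any claim that something is new, unique, unknown or untested is made for them only; others in the source may bear on it.

Compound 1, with the structure `COc1cccc(C(=O)Nc2ccc(Cl)cc2CN2C(=O)c3ccccc3C2=O)c1`, is the anchor of this small set. Within the data shown here, in an assay on CHO cells for positive allosteric modulation of metabotropic glutamate receptor 5 (Homo sapiens), read by FLIPR (a lower number here means that less compound is needed, a higher number that more compound is needed for the effect), compound 1 gives 1500 nM, and among the three values recorded it is the only one that is a number. Compound 2, with the structure `O=C(Nc1cccc(F)c1CN1C(=O)c2ccccc2C1=O)c1ccccn1`, gives in this assay > 100000 nM, which is a limit of the assay and not a number. Compound 3, with the structure `COc1ccc2c(c1OC)C(=O)N(Cc1cc(Br)ccc1NC(=O)c1ccccn1)C2=O`, likewise gives in this assay > 100000 nM, again a limit. The picture so far is therefore one measured number and (the limit of > 100000 nM in this assay, at which 2 of the 3 values shown sit).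

Compound 4, with the structure `O=C(Nc1ccc(Cl)cc1CN1C(=O)c2ccccc2C1=O)c1cncs1`, has not yet been measured. It differs from compound 1 in one place: 1,3-thiazol-5-yl in place of 3-methoxyphenyl on a carbonyl carbon. Among the measured compounds shown here, no step between two measured compounds matches this change, so any expectation rests on compound 1 alone and on the two limits of compound 2 and compound 3. Compound 4 is therefore expected to sit somewhat weaker than compound 1, with the step from compound 1 to compound 4 estimated at a 3.3-fold higher number from compound 1 to compound 4 (0.52 log units; beyond the scatter). The estimate for compound 4 in this assay is 5000 nM, within a range of 1000 nM to 40000 nM.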

Compound 4, half-maximal effective concentration: 1900 nM
Beside the measured number, compound 4's estimate is 2.6-fold (0.42 log units) above it; measured number inside the range.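

Compound 1's 3-methoxyphenyl, on a carbonyl carbon whose other neighbour is an amide-type nitrogen, can be exchanged for 1,3-thiazol-5-yl with no change that can be read in this assay: the step is a 1.3-fold higher number from compound 1 to compound 4 (0.10 log units; within the scatter), and compound 1 and compound 4 cannot be told apart. Among these compounds, this is the first step between two measured compounds, and it shows that the number at this place does not depend on keeping the six-membered aromatic ring of carbon only or its methoxy oxygen, since a five-membered aromatic ring with 2 hetero atoms and fewer heavy atoms serves as well. Nothing measured here gives a reason why the two compounds sit together.

From the compounds shown here alone, it remains open whether this place accepts groups of another kind on the carbonyl carbon, such as an amine, a carboxylic acid or a longer alkyl chain, and whether any group there moves the number beyond the scatter. Compound 2 and compound 3 each carry a limit of the assay and not a number, and each differs from compound 4 in more than one place, so neither can settle what this change would do on their cores.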